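The compounds below may be only part of what the source reports. "The series", "measured", "known", "first", "only" and "open" are said of these compounds alone.

Measured compounds:
- compound 1, `CC(C(=O)NCc1cc(C(C)(C)C)nn1C)c1ccc(NS(C)(=O)=O)c(F)c1`: "not active" (no number reported)
- compound 2, `CCCCCCn1nc(C(C)(C)C)cc1CNC(=O)C(C)c1ccc(NS(C)(=O)=O)c(F)c1`: 27.7 nM

Within the data shown here, in an assay on CHO cells for antagonist activity at transient receptor potential cation channel subfamily V member 1 (Homo sapiens), read by FLIPR and calcium flux, with a stated time of 6 min (on this read-out lower numbers stand for stronger inhibition and higher numbers for weaker inhibition), compound 1 gives "not active" (no number reported), so no single number stands for it and no step from it can be sized. In this assay compound 2 gives 27.7 nM. The two differ only in the group on the aromatic nitrogen of the shared core, and the larger group in compound 2 goes with a measurable number where compound 1 has none.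

Compound 3, `CC(C(=O)NCc1cc(C(C)(C)C)nn1-c1ccccc1)c1ccc(NS(C)(=O)=O)c(F)c1`, has not been measured. It differs from compound 1 by phenyl in place of methyl on an aromatic nitrogen. Among the measured compounds shown here, with no step between measured compounds recorded, the expectation rests on compound 2 alone: a larger group at this position was accompanied by a reported inhibition constant, so compound 3 is expected to give a number in this assay rather than to be reported inactive. Compound 3 is estimated at 60 nM, with a range of 10 nM to 400 nM, in this assay.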

Compound 3, inhibition constant: 8 nM
Compound 3: middle estimate off by 7.5-fold (0.88 log units), on the high side; measured number outside the range, below it.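

In this assay, phenyl in place of hexyl on the aromatic nitrogen gives a 3.5-fold lower number from compound 2 to compound 3 (0.54 log units; beyond the scatter), so an aromatic ring serves at this position at least as well as an open chain, and a measurable number does not depend on a long chain. Methyl in compound 1 remains the only group shown here without a number, and the steps from compound 1 cannot be read. Nothing shown accounts for the difference between phenyl and hexyl.

Open, as far as these compounds go, is where a shorter chain such as ethyl or propyl would fall between the methyl of compound 1 and the larger groups of compound 2 and compound 3. Also open, from the compounds shown here alone, is how a benzyl group, a chlorophenyl group or a pyridine ring would read at this position.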